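Phenoxypropyl Amide Variant in Rat Cell Cytotoxicity

The source may hold more compounds than are shown below. What is called first, only, known or untested is meant among the compounds shown, and "the series" means these compounds.

Of the compounds shown here, two that share one core have been measured in an ADME assay on L6 cells (Rattus norvegicus) for cytotoxicity; on this read-out higher numbers stand for weaker inhibition and lower numbers for stronger inhibition. Compound 1 `O=C(NCCCN1CCN(CCCNc2ccnc3cc(Cl)ccc23)CC1)c1ccc(Oc2ccccc2)cc1` gives 1400 nM. Compound 2 `O=C(NCCCN1CCN(CCCNc2ccnc3cc(Cl)ccc23)CC1)c1cccc(C(F)(F)F)c1` gives 30100 nM, the higher of the two numbers, and the gap down to compound 1 lies beyond the usual scatter, so compound 2 is the weaker inhibitor of cell growth in this pair. Compound 3 `O=C(CCCOc1ccccc1)NCCCN1CCN(CCCNc2ccnc3cc(Cl)ccc23)CC1` has not yet been measured in this assay. Compared with compound 2 it carries one change: 3-phenoxypropyl in place of 3-(trifluoromethyl)phenyl on a carbonyl carbon. For the measured compounds named here, no measured step of this kind exists here, so the direction rests on a loose hint: a downward move is expected because compound 1 also carries a phenoxy group and gives 1400 nM. For compound 3 a moderate decrease is expected, a 3.8-fold lower number from compound 2 to compound 3 (0.58 log units; beyond the scatter), and its result in this assay is estimated at 8000 nM, within a range of 2500 nM to 25000 nM.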

Compound 3, half-maximal inhibitory concentration: 9300 nM
Beside the measured number, compound 3's estimate is 1.2-fold (0.07 log units) below it, and the stated range covers the measured number.
By their numbers in this assay, from the lowest: compound 1; then compound 3; then compound 2.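

In this assay, for the compounds shown here, putting 3-phenoxypropyl in place of 3-(trifluoromethyl)phenyl on the carbonyl carbon gives a 3.2-fold lower number from compound 2 to compound 3 (0.51 log units; beyond the scatter), the first measured step at this position. Both groups have the same count of heavy atoms and one six-membered aromatic ring of carbon only, so the number moves at this position even with those counts unchanged, while the trifluoromethyl group leaves and a hydrogen-bond acceptor enters. Nothing measured here explains why the number moves.

This single step changes several features at once, so the compounds shown cannot say whether the chain, the oxygen or the loss of trifluoromethyl matters most. A 4-phenylbutyl group, which has no oxygen, or a shorter 2-phenoxyethyl chain on the same carbonyl carbon would help to separate these features.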